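The compounds below may be only part of what the source reports. "The series", "measured", "known", "first", "only" and "open" are said of these compounds alone.

Compound 1 `CC1(C)[C@H]2CC[C@]1(C)N(Cc1cn(-c3cccc(Cl)c3)nn1)C(=O)C2` gives 60 nM 
Compound 2 `COc1ccccc1-n1cc(CN2C(=O)C[C@@H]3CC[C@@]2(C)C3(C)C)nn1` gives 350 nM 
Compound 3 `CC1(C)[C@H]2CC[C@]1(C)N(Cc1cn(-c3cccc(Br)c3)nn1)C(=O)C2` gives 90 nM 

In a functional assay on A549 cells (Homo sapiens) for inhibition, read by MTT assay, with a stated time of 24 h (a lower number here means a stronger inhibitor, a higher number a weaker inhibitor), compound 3 at 90 nM holds the middle place of the three numbers. It sits within the scatter of compound 1 and well under compound 2.

Compound 4 `COc1ccc(-n2cc(CN3C(=O)C[C@@H]4CC[C@@]3(C)C4(C)C)nn2)cc1` has not yet been measured. It carries 4-methoxyphenyl in place of 3-bromophenyl on an aromatic nitrogen, a change counted as 4-methoxyphenyl in place of 3-bromophenyl on an aromatic nitrogen in the structures.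

For the measured compounds named here, three measured steps bear on this. Exchanging chloro for bromo made no clear difference, with a 1.5-fold higher number from compound 1 to compound 3 (0.18 log units; within the scatter) as the result. Moving to 2-methoxyphenyl did matter, since a 5.8-fold higher number from compound 1 to compound 2 (0.77 log units; beyond the scatter) lies beyond the scatter, and so does the step of a 3.9-fold lower number from compound 2 to compound 3 (0.59 log units; beyond the scatter) in the same pair of groups. Going by the values given here, no 4-methoxyphenyl compound has been measured, so this guide is only indirect. A modest rise in this assay is therefore expected, somewhat smaller than those two steps. The expected change is a 2.4-fold higher number from compound 3 to compound 4 (0.39 log units; beyond the scatter) on this reading. Compound 4 is estimated at 220 nM as a central value, with an expected range from 80 nM to 600 nM for its measurement.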

Compound 4, half-maximal inhibitory concentration: 50 nM
Compound 4: middle estimate off by 4.4-fold (0.64 log units), on the high side; measured number outside the range, below it.
By their numbers in this assay, from the lowest: compounds 4, 1 and 3 (each within the scatter of the next); then compound 2.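

In this assay, a methoxy group on this phenyl ring does not by itself go with a high number: moving from 2-methoxyphenyl to 4-methoxyphenyl gives a 7.0-fold lower number from compound 2 to compound 4 (0.85 log units; beyond the scatter), so where the methoxy group sits on the ring matters in this pair. Set against the halogen compounds, the new group shows no clear difference, with 3-bromophenyl replaced in a 1.8-fold lower number from compound 3 to compound 4 (0.26 log units; within the scatter) and 3-chlorophenyl replaced in a 1.2-fold lower number from compound 1 to compound 4 (0.08 log units; within the scatter). Compound 2 therefore stands apart from the other three, and no evidence on hand explains the difference.

The compounds shown leave open whether 3-methoxyphenyl would fall with compound 4 or with compound 2. They also leave open how groups of another kind would fare on this ring, such as an amine or a carboxylic acid in place of the methoxy group.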